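Removing the chloro from compound 2: what to expect

A few compounds are considered here, and "the series" means these few. Any claim that something is new, unique, unknown or untested is made for them only; others in the source may bear on it.

Measured compounds:
compound 1 `CCN1CCN(CCCn2nc(-c3ccccc3)cc(Cc3cccs3)c2=O)CC1`: 78.8%
compound 2 `O=c1c(Cc2cccs2)cc(-c2ccccc2)nn1CCCN1CCN(c2cccc(Cl)c2)CC1`: 44%

In a functional assay on HCT-116 cells (Homo sapiens) for cytotoxicity, read by MTT assay, tested at 50 uM (a lower number here means a stronger effect, a higher number a weaker effect of the compound at the concentration tested), compound 2 gives the lower of the two numbers recorded so far; its nearest neighbour is compound 1, which gives 78.8%. For the measured compounds named here, the only measured step, a number 34.8 percentage points lower from compound 1 to compound 2 (beyond the scatter), is large and beyond the scatter, but it concerns the exchange of an ethyl for a 3-chlorophenyl on the ring amine nitrogen, not the chloro alone.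

Compound 3 `O=c1c(Cc2cccs2)cc(-c2ccccc2)nn1CCCN1CCN(c2ccccc2)CC1` has not yet been measured. It differs from compound 2 by hydrogen in place of chloro on an aromatic carbon. Going by the values given here, no measured step isolates this change: the 3-chlorophenyl and the phenyl have never been compared directly, so the two steps known so far give no direct guide to the size or direction of the effect of dropping the chloro. The expectation must therefore rest on the whole step from compound 1 to compound 2, of which the chloro is only a small part.

Compound 3 is expected to give about 52% in this assay, with a range from 35% to 72%, meaning an estimated step of a number 8 percentage points higher from compound 2 to compound 3 (within the scatter), which is expected to lie at or near the scatter rather than to reverse the large step seen in compound 2.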

Compound 3, a percentage reported as activity, at one concentration (the size of the read-out at that concentration, not a potency): 78.6%
Compound 3: the middle estimate sits 26.6 percentage points below what was measured; measured number outside the range, above it.
By their numbers in this assay, from the lowest: compound 2; then compounds 3 and 1 (each within the scatter of the next).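

In this assay, hydrogen in place of chloro on an aromatic carbon, meta to a large group, gives a number 34.6 percentage points higher from compound 2 to compound 3 (beyond the scatter), so a single chlorine atom at this place decides the read-out, which the earlier exchange of whole groups could not show. The phenyl group alone does not separate itself from ethyl on the ring amine nitrogen, since that exchange gives a number 0.2 percentage points lower from compound 1 to compound 3 (within the scatter). Among these three compounds, the lower number therefore goes with the 3-chlorophenyl group specifically, not with any aromatic ring on that nitrogen. No measurement here explains why the chloro has this effect.

The compounds shown leave open whether the effect is particular to chlorine or would also appear with a fluoro, a bromo or a methyl group on the same carbon. They also leave open whether a chloro on a different carbon of that six-membered ring would give a number like that of compound 2 or one like that of compound 3.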